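An Ester in Place of an Aryl Ring

The compounds below may be only part of what the source reports. "The series", "measured", "known", "first", "only" and "open" are said of these compounds alone.

In a functional assay on MCF7 cells (Homo sapiens) for cytotoxicity, read by MTT assay, with a stated time of 48 h (a lower number here means a stronger inhibitor, a higher number a weaker inhibitor), the three measured compounds give the following numbers:
compound 1 `CCN(CC)c1ccc2cc(C(=O)c3ccc(N4CCN(C(=O)CN5CCNCC5)CC4)cc3)oc2c1`: 5340 nM
compound 2 `CCN(CC)c1ccc2cc(C(=O)c3ccc(N4CCN(C(=O)CN5CCN(Cc6ccc(F)c(F)c6)CC5)CC4)cc3)oc2c1`: 9220 nM
compound 3 `CCN(CC)c1ccc2cc(C(=O)c3ccc(N4CCN(C(=O)CN5CCN(Cc6ccc(C(F)(F)F)cc6)CC5)CC4)cc3)oc2c1`: 18200 nM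

Compound 3 has the highest number of the three. Its gap to compound 2 is small, a 2.0-fold higher number from compound 2 to compound 3 (0.30 log units; within the scatter), while the gap to compound 1 is larger, a 3.4-fold higher number from compound 1 to compound 3 (0.53 log units; beyond the scatter). Compound 4 `CCOC(=O)CN1CCN(CC(=O)N2CCN(c3ccc(C(=O)c4cc5ccc(N(CC)CC)cc5o4)cc3)CC2)CC1` is the next step from compound 3: ethoxycarbonyl in place of 4-(trifluoromethyl)phenyl on a saturated chain carbon bound to an amine nitrogen in a ring. Within the data shown here, two measured steps bear on this. The step of a 3.4-fold higher number from compound 1 to compound 3 (0.53 log units; beyond the scatter) shows that putting the 4-(trifluoromethyl)benzyl group on the ring nitrogen raised the number, and the step of a 1.7-fold higher number from compound 1 to compound 2 (0.24 log units; within the scatter) shows a similar but smaller effect for the 3,4-difluorobenzyl group. Taking the aryl ring away again therefore points back toward the number of compound 1. Among the measured compounds shown here, no measured compound carries an ethoxycarbonyl group, so its own contribution is unknown. The expected step is a 2.4-fold lower number from compound 3 to compound 4 (0.39 log units; beyond the scatter), a lower number. Compound 4 is estimated at 7500 nM in this assay, with a range from 3000 nM to 18000 nM.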

Compound 4, half-maximal inhibitory concentration: > 40000 nM
Compound 4 was reported as a limit (the forecaster's own chance of this, stated with the estimate: 5%); at least 5.3-fold (0.72 log units) between middle value and limit.
By their numbers in this assay, from the lowest: compounds 1, 2 and 3 (each within the scatter of the next, the first and the last beyond it). At a limit, above all of these: compound 4.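

In this assay compound 4 is reported only as a limit: the limit of > 40000 nM in this assay, at which 1 of the 4 values shown sits. The steps to it can still be read as minimum sizes, and all lie beyond the scatter: an at least 2.1-fold higher number from compound 3 to compound 4 (0.34 log units; beyond the scatter), an at least 4.3-fold higher number from compound 2 to compound 4 (0.63 log units; beyond the scatter) and an at least 7.4-fold higher number from compound 1 to compound 4 (0.87 log units; beyond the scatter). Taking the aryl ring away therefore did not return the number toward that of compound 1, so on an amine nitrogen in a ring, a group without an aryl ring, (ethoxycarbonyl)methyl, raised the number further than either benzyl group did.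

Going by these compounds, it remains open whether this change depends on the whole ester, which a carboxylic acid or a simple ethyl group in place of ethoxycarbonyl would help to test. An unsubstituted benzyl group would show how much the fluorine-bearing substituents contribute in compound 2 and compound 3.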